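Inverting One Stereocentre of Compound 2

The compounds below may be only part of what the source reports. "The series", "measured", "known", "first", "only" and "open" are said of these compounds alone.

In a physicochemical assay for solubility, in phosphate buffer, measured as kinetic solubility, at pH 7.4 (on this read-out higher numbers stand for higher solubility and lower numbers for lower solubility), compound 2 `COc1ccc(CC[C@H](O)C[C@@H](O)c2cc(-c3ccccc3)on2)cc1` gives 25000 nM. Compound 3 `COc1cccc(CC[C@H](O)C[C@@H](O)c2cc(-c3ccccc3)on2)c1` gives 25000 nM, level with compound 2, and the two share the highest number of the set. Compound 1 `COc1ccc(CC[C@H](O)C[C@H](O)c2cc(-c3ccc(OC)cc3)on2)cc1` gives 12000 nM, a lower number that lies beyond the scatter.

Compound 4 `COc1ccc(CC[C@H](O)C[C@H](O)c2cc(-c3ccccc3)on2)cc1` departs from compound 2 in one way only: the two compounds have the same atoms and bonds and differ only in configuration as drawn: 1 of 2 stereo elements differ; a stereocentre at a saturated chain carbon is drawn R in compound 2 and S in compound 4. Going by the values given here, no measured pair isolates a change of configuration. Among the compounds with values here, the one measured step is no change at the digits printed from compound 2 to compound 3 (within the scatter), and it places 3-methoxyphenyl where 4-methoxyphenyl stood, leaving the configuration untouched, so it offers only indirect guidance. Compound 4 is drawn with the same configuration as compound 1, which also differs in its substituents, so compound 1 with its 12000 nM justifies only a slight downward allowance. The expected change is small, with a 1.3-fold lower number from compound 2 to compound 4 (0.10 log units; within the scatter) estimated to stay within the scatter. For compound 4 the estimated value is 20000 nM, with an expected range from 10000 nM to 40000 nM.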

Compound 4, solubility: 25000 nM
The estimate for compound 4 lay 1.3-fold (0.10 log units) below the measured number, within the range that was stated.
By their numbers in this assay, from the lowest: compound 1; then compounds 2, 3 and 4 (each within the scatter of the next).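

In this assay, going by these compounds alone, the configuration at this saturated chain carbon now has a direct reading that the earlier compounds could not give, with R changed to S producing no change at the digits printed from compound 2 to compound 4 (within the scatter). With the S configuration held fixed, hydrogen in place of methoxy on an aromatic carbon produces a 2.1-fold higher number from compound 1 to compound 4 (0.32 log units; beyond the scatter), so the configuration shared by compound 1 and compound 4 does not by itself go with a lower number. The reading of the configuration rests on a pair with no other difference: the fact that compounds 2 and 4 differ only in the configuration as drawn.

The compounds shown leave open whether the other stereocentre can be inverted with as little consequence, and whether the methoxy-to-hydrogen step would read the same with the R configuration. They also leave open how the number would respond if an amine or a carboxylic acid stood in place of the methoxy group.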